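The source may report more compounds than this note shows. Statements on the series, on what has been measured and on what is new or still open speak of the compounds shown alone.

Measured so far in an assay on isolated protein for binding affinity to corticotropin-releasing factor receptor 1 (Homo sapiens); a lower number here means a stronger inhibitor, a higher number a weaker inhibitor:

Compound 1, `CC(=O)/C(=N\Nc1ccccc1)Oc1cccc(Cl)c1`, gives > 10000 nM, which is a limit of the assay and not a number.
Compound 2, `CC(=O)/C(=N\Nc1ccccc1C(F)(F)F)Nc1cccc(Cl)c1`, gives 538 nM; 538 nM (2 entries).
Compound 3, `CC(=O)/C(=N\Nc1ccccc1C(F)(F)F)Oc1cccc(Cl)c1`, gives > 10000 nM, again a limit of the assay and not a number.

Compound 3 therefore stands at the limit of > 10000 nM in this assay, at which 2 of the 3 values shown sit, alongside compound 1; only compound 2 gives a number, and compound 2 differs from compound 3 in more than one place, so its value says nothing direct about the step at hand. Among the compounds with values here, the one measured step that touches compound 3, a step that the two limits leave unreadable from compound 1 to compound 3, runs between two limits and its size cannot be read.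

Compound 4, `CC(=O)/C(=N\Nc1ccccc1C)Oc1cccc(Cl)c1`, differs from compound 3 in one place: methyl in place of trifluoromethyl on an aromatic carbon. Both neighbours of this position in the series, hydrogen in compound 1 and trifluoromethyl in compound 3, sit at the limit, so no step beyond the scatter is expected in this assay, and compound 4 is expected to sit at the limit as well, with a step that the limit leaves unreadable from compound 3 to compound 4 as the expected step. Compound 4 is estimated at 20000 nM, in the range 5000 nM to 100000 nM.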

Compound 4, inhibition constant: > 10000 nM
Compound 4 was reported as a limit; the forecaster's own chance of this, stated with the estimate: 85%; the middle value is on the limit's open side.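

Compound 4 joins compound 1 and compound 3 at a limit of the assay, not a number, in this assay, so no step among these three compounds can be read: the limit of > 10000 nM in this assay, at which 3 of the 4 values shown sit.

The compounds shown leave open whether hydrogen, methyl and trifluoromethyl on this aromatic carbon differ at all in this assay.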